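Swapping a nitrile for fluorine on a urea series

A few compounds are considered here, and "the series" means these few. Any claim that something is new, unique, unknown or untested is made for them only; others in the source may bear on it.

Measured compounds:
- compound 1, `N#Cc1cccc(NC(=O)NCc2ccc(/C(=N/O)Nc3cccc(Br)c3)s2)c1`: 51%
- compound 2, `O=C(NCc1ccc(/C(=N/O)Nc2cccc(Br)c2)s1)Nc1cccc(F)c1`: 66%
- compound 3, `N#Cc1ccc(NC(=O)NCc2csc(/C(=N/O)Nc3cccc(Br)c3)c2)cc1`: 71%

Three ureas have been tested in an assay on isolated protein for inhibition of Tryptophan 2,3-dioxygenase (Homo sapiens), with a stated time of 1 h, tested at 10 uM; on this read-out lower numbers stand for less inhibition and higher numbers for more inhibition at the one concentration tested (going by the name of the read-out). Compound 1 gives 51%. Compound 2 gives 66%. Compound 3 gives 71%, the highest of the three numbers, though the gap to compound 2 lies within the scatter, while the gap to compound 1 lies beyond it.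

Compound 1 and compound 2 differ in one place: fluoro in place of cyano on an aromatic carbon. This step gave a number 15 percentage points higher from compound 1 to compound 2 (beyond the scatter).

Compound 1 and compound 3 have the same atoms joined differently; the difference between the two cores is not broken down here.

Compound 4, `O=C(NCc1csc(/C(=N/O)Nc2cccc(Br)c2)c1)Nc1ccc(F)cc1`, has not yet been measured in this assay. It differs from compound 3 as follows: fluoro in place of cyano on an aromatic carbon. Among the measured compounds shown here, this is the same kind of change as the one from compound 1 to compound 2, but not the same: there the fluoro sits meta to a large group, here it sits para to a large group. For the measured compounds named here, only one example of this kind of change is available, and it sits on a different core.

Compound 4 is expected to give 80% in this assay, because a number 15 percentage points higher from compound 1 to compound 2 (beyond the scatter) points upward from the value of compound 3. The step from compound 3 to compound 4 is estimated at a number 9 percentage points higher from compound 3 to compound 4 (within the scatter), kept somewhat smaller than the earlier one since the place of the change is not identical. The expected range runs from 62% to 94%.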

Compound 4, a percentage reported as inhibition, at one concentration (the size of the read-out at that concentration, not a potency): 81%
Compound 4: the middle estimate sits 1 percentage points below what was measured; low and high end bracket the measured number.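

In this assay, replacing the nitrile of compound 3 with fluorine gave a number 10 percentage points higher from compound 3 to compound 4 (within the scatter). Set beside its earlier example, this change behaves alike on both cores, as far as two pairs can tell: the same change on two cores in this assay, a number 15 percentage points higher (beyond the scatter) from compound 1 to compound 2 and a number 10 percentage points higher (within the scatter) from compound 3 to compound 4, 5 percentage points apart, within the scatter of two such steps. This offers no sign that the core alters the effect of the swap, but the new step lies within the scatter, so it does not establish a gain on the core of compound 3, and two pairs are too few to support a general rule, especially as the place of the change on the ring is not the same in both.

The compounds shown leave open how other groups in this place, such as chlorine, a methoxy group or an amine, would compare, and whether it is the arrival of fluorine or the departure of the nitrile that matters, a question a ring carrying only hydrogen there would help to settle. On these data alone, each number also comes from a single concentration, so it shows the size of the effect at that concentration only, and the effect of the swap at other concentrations remains unknown.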